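Ethoxy step on compound 2: cytotoxicity notes

The compounds below may be only part of what the source reports. "The series", "measured", "known", "first", "only" and "open" are said of these compounds alone.

In a functional assay on MT4 cells (Homo sapiens) for cytotoxicity, read by MTT assay (on this read-out lower numbers stand for higher toxicity in this test and higher numbers for lower toxicity in this test), compound 1 (`Cc1c(O)nc(S(=O)(=O)Cc2ccc([N+](=O)[O-])cc2)nc1Cc1c(Cl)cccc1Cl`) gives > 53000 nM as a limit of the assay, not as a number. Compound 2 (`Cc1c(O)nc(SCc2ccccc2)nc1Cc1c(Cl)cccc1Cl`) gives > 64000 nM as a limit too, so it stands in this series without a number. No order between the two can be read from these limits.

Compound 3 (`CCOc1ccc(CSc2nc(O)c(C)c(Cc3c(Cl)cccc3Cl)n2)cc1`) differs from compound 2 by one change, phenyl to 4-ethoxyphenyl (ethoxy in place of hydrogen on an aromatic carbon), with ethoxy in place of hydrogen on an aromatic carbon, para to a large group. Among the compounds with values here, no measured pair shows what such a change does in this assay on its own. The expectation therefore rests on compound 2, whose limit > 64000 nM is the nearest anchor. A small shift towards lower numbers is expected, perhaps none beyond the scatter, and the estimated at least 1.2-fold lower number from compound 2 to compound 3 (0.10 log units; that floor lies within the scatter) should be read in that sense. Another limit instead of a number would be no surprise. The expected value for compound 3 is 50000 nM (estimated range 20000 nM to 100000 nM).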

Compound 3, half-maximal cytotoxic concentration: > 58000 nM
Compound 3: only a limit was reported; the forecaster's own chance of this, stated with the estimate: 55%; middle value at least 1.1-fold (0.06 log units) away from the limit.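

In this assay compound 3 gives > 58000 nM, a limit of the assay and not a number. Compound 2 also carries only a limit, so the step from compound 2 to compound 3 cannot be read. The compounds shown leave open what actual value any of them has, and what phenyl to 4-ethoxyphenyl does in this test.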